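The source may hold more compounds than are shown below. What is called first, only, known or untested is meant among the compounds shown, and "the series" means these compounds.

Compound 1 (`O=C1CC(Oc2ncccn2)CN1c1cnn2c1CN(C(=O)Nc1cc(F)c(F)c(F)c1)C(C1CC1)C2`) gives > 200000 nM in a toxicity assay on HepG2 2.2.15 cells (Homo sapiens) for cytotoxicity, read by CellTiter-Glo (a higher number here means that more compound is tolerated, a lower number that less compound is tolerated), as its only result. That figure is a limit of the assay and not a number. Compound 1 therefore stands at the limit of > 200000 nM in this assay, at which 1 of the 3 values shown sits, and has no exact place beside its relatives.

Two relatives do have numbers in this assay here: compound 2 (`O=C(Nc1cc(F)c(F)c(F)c1)N1Cc2c(-c3ccc(F)cc3F)cnn2CC1C1CC1`) gives 32100 nM and compound 3 (`O=C1OC(c2ccc(F)cc2)CN1c1cnn2c1CN(C(=O)Nc1cc(F)c(F)c(F)c1)C(C1CC1)C2`) gives 3560 nM in the same test.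

Compound 4 (`O=C1CC(c2ncc(F)cn2)CN1c1cnn2c1CN(C(=O)Nc1cc(F)c(F)c(F)c1)C(C1CC1)C2`) differs from compound 1 in one place, with 5-fluoropyrimidin-2-yl in place of (pyrimidin-2-yl)oxy on a saturated ring carbon. For the measured compounds named here, no measured pair differs in one place only, so the size of this step rests on judgement.

Compound 2 at 32100 nM and compound 3 at 3560 nM both carry a fluorine-bearing aromatic ring, as compound 4 does and compound 1 does not. Three compounds are a thin basis, yet in this assay a move beyond the scatter towards less compound tolerated is expected.

The expected step is an at least 3.3-fold lower number from compound 1 to compound 4 (0.52 log units; beyond the scatter) in this test, and it could still end at the limit. Compound 4 is estimated at 60000 nM with an expected range from 15000 nM to 200000 nM in this test.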

Compound 4, half-maximal cytotoxic concentration: 115000 nM
For compound 4 the middle estimate is 1.9-fold (0.28 log units) below the measured one, within the range that was stated.
By their numbers in this assay, from the lowest: compound 3; then compound 2; then compound 4. At a limit, above all of these: compound 1.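

For the compounds shown here, replacing (pyrimidin-2-yl)oxy with 5-fluoropyrimidin-2-yl on a saturated ring carbon gives the only step that can be read at this position in this assay, and it is an at least 1.7-fold lower number from compound 1 to compound 4 (0.24 log units; that floor lies within the scatter). Compound 1 stands at a limit of the assay and not at a number: the limit of > 200000 nM in this assay, at which 1 of the 4 values shown sits.

The step is therefore only a floor, and since that floor lies within the usual scatter, it does not establish a real fall. What compound 4 adds is an exact value at this position, 115000 nM, against which another group on this ring carbon could be set.

The swap removes an oxygen and brings in a fluorine in one move, so the compounds shown cannot separate what each of the two contributes. They also leave open what plain pyrimidin-2-yl, an amine or a carboxylic acid on this same saturated ring carbon would give in this assay.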